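This account rests on a few compounds, and the source may have more. Where it says the series, first, only, none or still open, it means among the compounds named here.

Series notes. Three measured compounds share one core: compound 1 `CC(C)(Oc1ccc([C@H]2CC[C@]3(CC2)OOC2(O3)C3CC4CC(C3)CC2C4)cc1)C(=O)O`, compound 2 `O=C(O)COc1ccc([C@H]2CC[C@]3(CC2)OOC2(O3)C3CC4CC2CC(C3)C4(F)F)cc1` and compound 3 `O=C(O)c1cc([C@H]2CC[C@]3(CC2)OOC2(O3)C3CC4CC(C3)CC2C4)ccc1O`. In an ADME assay on microsomes from liver (Homo sapiens) for metabolic stability, using NADPH, with a stated time of 60 min, in the presence of a further agent that is not named here (a lower number here means slower removal, a higher number faster removal of the compound), compound 2 gives 23 mL.min-1.g-1. In this assay compound 3 gives 108 mL.min-1.g-1. For compound 1 the reading in this assay is a limit of the assay and not a number, < 7 mL.min-1.g-1. That places compound 1 at the floor of the numbers shown, and the evidence for it is simply (the limit of < 7 mL.min-1.g-1 in this assay, at which 1 of the 3 values shown sits).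

The next member is compound 4 `O=C(O)CN1CCC(Oc2ccc([C@H]3CC[C@]4(CC3)OOC3(O4)C4CC5CC(C4)CC3C5)cc2)CC1`. Its difference from compound 1: 1-(carboxymethyl)piperidin-4-yl in place of 1-carboxy-1-methylethyl on an oxygen on an aromatic ring. For the measured compounds named here, no measured pair changes this position, so the size of the step in this assay has no direct precedent. A rise beyond the scatter is expected, with the compound moving off the limit into the measurable range, though a reading again at the limit is not excluded.

Compound 4 is expected at 15 mL.min-1.g-1, within a range from 5 mL.min-1.g-1 to 45 mL.min-1.g-1. The estimated step from compound 1 to compound 4, an at least 2.1-fold higher number from compound 1 to compound 4 (0.33 log units; beyond the scatter), is expected to be a moderate increase.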

Compound 4, intrinsic clearance in microsomes: < 7 mL.min-1.g-1
Compound 4: a limit, no number; the forecaster's own chance of this, stated with the estimate: 30%; middle value at least 2.1-fold (0.33 log units) from the limit.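

Compound 1 and compound 4 both read as a limit and not a number in this assay, so no step can be read between them: the limit of < 7 mL.min-1.g-1 in this assay, at which 2 of the 4 values shown sit.

The compounds shown leave open whether 1-(carboxymethyl)piperidin-4-yl and 1-carboxy-1-methylethyl differ at all in this assay.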